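The source may report more compounds than this note shows. Statements on the series, on what has been measured and on what is new or still open speak of the compounds shown alone.

Measured compounds in an assay on isolated protein for inhibition of proto-oncogene tyrosine-protein kinase receptor Ret variant V804M (Homo sapiens), read by 33P incorporation, with stated times of 15 min and 40 min; on this read-out lower numbers stand for stronger inhibition and higher numbers for weaker inhibition:
- compound 1 `O=C(Nc1ccc(Br)cc1)Nc1ccc(Nc2ncnc3c2OCCN3)cc1`: 2350 nM
- compound 2 `Cc1cc(C)cc(NC(=O)Nc2ccc(Nc3ncnc4c3OCCN4)cc2)c1`: 971 nM

Compound 2 stands lowest of the two numbers in this assay; its nearest neighbour is compound 1, and the step between them, a 2.4-fold lower number from compound 1 to compound 2 (0.38 log units; beyond the scatter), is the only one measured. That step swaps the group on the same amide-type nitrogen, so it is the one that bears on the next change, and it was modest.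

Compound 3 `CC(C)(C)c1csc(NC(=O)Nc2ccc(Nc3ncnc4c3OCCN4)cc2)n1` differs from compound 2 as 4-(tert-butyl)-1,3-thiazol-2-yl in place of 3,5-dimethylphenyl on an amide-type nitrogen. Among the compounds with values here, no measured step replaces a six-membered aromatic ring of carbon only with a five-membered aromatic ring with 2 hetero atoms, so the direction rests on the single swap seen so far, which stayed small. A step of similar or smaller size, in either direction, is therefore expected in this assay.

Compound 3 is expected to give about 800 nM in this assay, within 300 nM to 2500 nM. This estimate means a step of a 1.2-fold lower number from compound 2 to compound 3 (0.08 log units; within the scatter), expected to stay near the scatter.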

Compound 3, half-maximal inhibitory concentration: 5170 nM
The estimate for compound 3 lay 6.5-fold (0.81 log units) below the measured number; the whole stated range lies below it.
By their numbers in this assay, from the lowest: compound 2; then compound 1; then compound 3.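

In this assay, the group on the amide-type nitrogen can move the number in either direction: a 5.3-fold higher number from compound 2 to compound 3 (0.73 log units; beyond the scatter) runs opposite to a 2.4-fold lower number from compound 1 to compound 2 (0.38 log units; beyond the scatter) and shows that this position does not tolerate every aryl swap equally. The 4-(tert-butyl)-1,3-thiazol-2-yl group also compares unfavourably with 4-bromophenyl, with a 2.2-fold higher number from compound 1 to compound 3 (0.34 log units; beyond the scatter) as the step, so it gives the highest number of the three groups. No supporting data explain this rise.

This change alters the ring and its substituents together, leaving their separate contributions unresolved. A 4-(tert-butyl)phenyl group or a 4-methyl-1,3-thiazol-2-yl group on the same nitrogen would help show whether the thiazole ring or the tert-butyl group tracks with the higher number.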